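This account rests on a few compounds, and the source may have more. Where it says the series, first, only, none or still open, it means among the compounds named here.

In a functional assay on MCF7 cells (Homo sapiens) for antiproliferative activity, read by sulforhodamine B assay, with a stated time of 48 h (a higher number here means a weaker inhibitor, a lower number a stronger inhibitor), compound 1, `O=C1NCCN1c1ccc(S(=O)(=O)Nc2ccc(F)cc2)cc1`, gives 690 nM. Compound 2, `CCCCCCCc1ccc(NS(=O)(=O)c2ccc(N3CCNC3=O)cc2)cc1`, gives > 1000 nM, which is a limit of the assay and not a number. Compound 2 therefore has no exact place on the scale. Putting heptyl in place of fluoro on an aromatic carbon produced an at least 1.4-fold higher number from compound 1 to compound 2 (0.16 log units; that floor lies within the scatter).

Compound 3, `CC(C)(C)c1ccc(NS(=O)(=O)c2ccc(N3CCNC3=O)cc2)cc1`, keeps the shared core and carries tert-butyl in place of heptyl on an aromatic carbon, the same carbon that changed in the earlier step. The counted difference is tert-butyl in place of heptyl on an aromatic carbon.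

The step from fluoro to heptyl is the only measured one that bears on this change. It gives a floor rather than a size, and that floor lies within the scatter, so it points to no firm direction. No clear move beyond the scatter is therefore expected in this assay, and a number near the level of the two measured compounds seems most likely. The expected change is an at least 1.1-fold lower number from compound 2 to compound 3 (0.04 log units; that floor lies within the scatter). For compound 3 the estimated value is 900 nM, with an expected range from 300 nM to 2500 nM.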

Compound 3, half-maximal inhibitory concentration: > 1000 nM
Compound 3: no number, only a limit; the forecaster's own chance of this, stated with the estimate: 40%; at least 1.1-fold (0.04 log units) between middle value and limit.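

With tert-butyl on the same aromatic carbon, compound 3 gives > 1000 nM in this assay, which is a limit of the assay and not a number, so a carbon group of 4 heavy atoms, against 7 in heptyl, also fails to yield a measured value here. Measured against fluoro, the change gives an at least 1.4-fold higher number from compound 1 to compound 3 (0.16 log units; that floor lies within the scatter), and this floor, like the one for heptyl, sets no firm direction, so neither carbon group can yet be said to weaken the compound. The step between the two limits cannot be read, because compound 2 and compound 3 sit at the same ceiling, and their order remains unknown: the limit of > 1000 nM in this assay, at which 2 of the 3 values shown sit.

Going by these compounds, how far either true value lies past that limit stays open, and with it the real size of any loss on leaving fluoro. Also open, on these data alone, is how a smaller carbon group such as methyl, or a different kind of group such as an amine or a carboxylic acid, would read on this aromatic carbon in this assay.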